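Removing the methyl from the fused ring of compound 2

The source may hold more compounds than are shown below. What is called first, only, known or untested is meant among the compounds shown, and "the series" means these compounds.

In a functional assay on the whole organism (Hindlimb, strain albino) with Mus musculus as the target, in the maximal electroshock model, with a stated time of 0.5 h (a lower number here means that less compound is needed, a higher number that more compound is needed for the effect), compound 2 `COc1ccc(C2CC(Nc3nc4ccc(C)cc4s3)=NN2C(C)=O)cc1` gives 37.3 umol/kg, the lowest number among the three measured compounds. Its nearest neighbour is compound 3 `CC(=O)N1N=C(Nc2nc3ccc(C)cc3s2)CC1c1ccccc1`, which in this assay gives 106 umol/kg; the step of a 2.8-fold higher number from compound 2 to compound 3 (0.45 log units; beyond the scatter) comes from a single change, hydrogen in place of methoxy on an aromatic carbon. Furthest away lies compound 1 `COc1ccc(/C=C/C(=O)Nc2nc3ccc(Cl)cc3s2)cc1O`, a cinnamamide with a different core, which in this assay gives 320 umol/kg.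

Compound 4 `COc1ccc(C2CC(Nc3nc4ccccc4s3)=NN2C(C)=O)cc1` is compound 2 with one alteration: hydrogen in place of methyl on an aromatic carbon. The change sits on the fused two-ring part of the molecule, not on the ring where the methoxy of compound 2 is varied in compound 3. For the measured compounds named here, no measured pair shows what loss of this methyl does, so the only guidance is indirect: the single measured step, from compound 2 to compound 3, is modest in size and involves a different group on a different ring, and the loss here is of a single heavy atom with no donors or acceptors. A small shift is therefore expected, most likely toward a somewhat higher number but not necessarily beyond the scatter.

Compound 4 is estimated at 55 umol/kg in this assay, within 22 umol/kg to 140 umol/kg. This expectation corresponds to a step of a 1.5-fold higher number from compound 2 to compound 4 (0.17 log units; within the scatter).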

Compound 4, dose for half-maximal effect: 226 umol/kg
Compound 4: the middle estimate sits 4.1-fold (0.61 log units) below what was measured, and the stated range ends below it.
By their numbers in this assay, from the lowest: compound 2; then compound 3; then compounds 4 and 1 (each within the scatter of the next).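

Hydrogen in place of methyl on this aromatic carbon gives a 6.1-fold higher number from compound 2 to compound 4 (0.78 log units; beyond the scatter) in this assay, so this methyl on the fused system of two rings cannot be dropped without a cost beyond the scatter, even though it is a single carbon and carries no hydrogen-bond donors or acceptors. For the compounds shown here, until now the only measured single change was at the methoxy, a 2.8-fold higher number from compound 2 to compound 3 (0.45 log units; beyond the scatter), and this result adds a second site on the molecule, in a different ring, where a simple loss from compound 2 raises the number needed for the effect, so compound 2 is now reached from two sides by single changes that each go the same way. Nothing measured here bears on the reason for this step.

The compounds shown leave open whether a different group at this carbon, such as ethyl, fluoro or trifluoromethyl, would hold or lower the number of compound 2. They also leave open whether the loss of the methyl costs the same in the absence of the methoxy, since no compound shown carries hydrogen in both places.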